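The source may hold more compounds than are shown below. What is called first, only, known or untested is meant among the compounds shown, and "the series" means these compounds.

Compound 3 `O=S(=O)(NCCCNCc1ccccc1)c1cc(C(F)(F)F)cc(C(F)(F)F)c1` gives 11000 nM in a functional assay on MIA PaCa-2 cells (Homo sapiens) for inhibition, read by MTT assay, with a stated time of 72 h (a lower number here means a stronger inhibitor of growth, a higher number a weaker inhibitor of growth), the highest number of the three measured. Compound 1 `CC(C)(C)c1ccc(CNCCCNS(=O)(=O)c2cc(C(F)(F)F)cc(C(F)(F)F)c2)cc1` gives 2300 nM and compound 2 `O=S(=O)(NCCCNCc1ccc(C(F)(F)F)cc1)c1cc(C(F)(F)F)cc(C(F)(F)F)c1` gives 2500 nM. The steps of a 4.8-fold higher number from compound 1 to compound 3 (0.68 log units; beyond the scatter) and a 4.4-fold higher number from compound 2 to compound 3 (0.64 log units; beyond the scatter) both show that taking a group off the aromatic carbon of the benzyl part raises the number, while a 1.1-fold higher number from compound 1 to compound 2 (0.04 log units; within the scatter) lies within the scatter. Compound 4 `O=S(=O)(NCCCNCc1cccc2ccccc12)c1cc(C(F)(F)F)cc(C(F)(F)F)c1` carries the change (naphthalen-1-yl in place of phenyl on a saturated chain carbon bound to an amine nitrogen), a larger aromatic part in place of the single ring. For the measured compounds named here, no measured step covers this exact change. The two steps into compound 3 point towards more carbon on that ring lowering the number, so a modest lowering is expected, a 2.4-fold lower number from compound 3 to compound 4 (0.39 log units; beyond the scatter). Compound 4 is expected near 4500 nM, within 1500 nM to 13000 nM.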

Compound 4, concentration for 50% growth inhibition: 2800 nM
The estimate for compound 4 lay 1.6-fold (0.21 log units) above the measured number; the measured number falls inside the stated range.
By their numbers in this assay, from the lowest: compounds 1, 2 and 4 (each within the scatter of the next); then compound 3.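

In this assay, naphthalen-1-yl in place of phenyl on a saturated chain carbon bound to an amine nitrogen gives a 3.9-fold lower number from compound 3 to compound 4 (0.59 log units; beyond the scatter), so an added fused aromatic ring also lowers the number, not only a substituent on the single ring. The steps of a 1.1-fold higher number from compound 2 to compound 4 (0.05 log units; within the scatter) and a 1.2-fold higher number from compound 1 to compound 4 (0.09 log units; within the scatter) lie within the scatter, so naphthalen-1-yl, 4-(trifluoromethyl)phenyl and 4-(tert-butyl)phenyl cannot be told apart here.

On these data alone, whether a pyridyl group or a carboxylic acid on the phenyl ring holds this level stays open, as does the effect of a longer chain. Nothing available explains why these three groups read alike.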